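The source may report more compounds than this note shows. Statements on the series, on what has been measured and on what is new or still open speak of the compounds shown alone.

The measured compounds:
Compound 1, `COc1cc[nH]c1/C=C1\C(=O)Nc2ccc([N+](=O)[O-])cc21`, gives 7460 nM in a functional assay on MDA-MB-435 cells (Homo sapiens) for antiproliferative activity, read by MTT assay, with a stated time of 5 days; a higher number here means a weaker inhibitor, a lower number a stronger inhibitor.
Compound 2, `COc1cc[nH]c1/C=C1\C(=O)Nc2ccc([N+](=O)[O-])c(N3CCC(O)CC3)c21`, gives 46 nM in this assay.

On the numbers shown, compound 2 stands lowest of the two. For the measured compounds named here, its nearest neighbour is compound 1, and the single measured step, a 160-fold lower number from compound 1 to compound 2 (2.21 log units; beyond the scatter), places compound 2 well beyond the scatter below compound 1.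

Compound 3, `COc1cc[nH]c1/C=C1\C(=O)Nc2ccc([N+](=O)[O-])c(N3CC[C@@H](N)C3)c21`, is not yet measured. It differs from compound 2 in one place: 3-aminopyrrolidin-1-yl in place of 4-hydroxypiperidin-1-yl on an aromatic carbon. Going by the values given here, the one measured step that bears on this position is a 160-fold lower number from compound 1 to compound 2 (2.21 log units; beyond the scatter), which shows how much a non-aromatic ring on this aromatic carbon changes the number relative to a hydrogen there. Compound 3 keeps a ring of this kind on the same carbon, so the data give no ground to expect a step of that size again in either direction. The exchange of one such ring for another is expected to leave the number within or near the scatter. The estimated step is a 1.1-fold higher number from compound 2 to compound 3 (0.04 log units; within the scatter). Compound 3 is therefore expected to give 50 nM in this assay, with a range from 15 nM to 160 nM.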

Compound 3, half-maximal inhibitory concentration: < 10 nM
Compound 3: a limit, no number; the forecaster's own chance of this, stated with the estimate: 2%; at least 5.0-fold (0.69 log units) between middle value and limit.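

In this assay compound 3 reads as a limit and not as a number: the limit of < 10 nM in this assay, at which 1 of the 3 values shown sits. The earlier compounds shown here showed only what a non-aromatic ring does on this aromatic carbon, ortho to a nitro group, compared with a hydrogen there, whereas the new result shows that the choice of ring also matters: the exchange of 4-hydroxypiperidin-1-yl for 3-aminopyrrolidin-1-yl gives an at least 4.6-fold lower number from compound 2 to compound 3 (0.66 log units; beyond the scatter), and this step is a bound on the change, not its full size. Set against the hydrogen of compound 1, the same group gives an at least 740-fold lower number from compound 1 to compound 3 (2.87 log units; beyond the scatter), so compound 3 also stands far beyond the scatter from the compound without a ring.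

The compounds shown leave open whether the step follows from the five-membered ring, the amine in place of the hydroxyl, or the two together, since both differences arrive in one exchange; a 4-aminopiperidin-1-yl or a 3-hydroxypyrrolidin-1-yl group on the same carbon would separate them. They also leave open how far the defined stereocentre of the 3-aminopyrrolidin-1-yl group counts, as its mirror form is not among them.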